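A few compounds are considered here, and "the series" means these few. Any claim that something is new, unique, unknown or untested is made for them only; others in the source may bear on it.

Measured so far, in the same assay:
Compound 1 `Cc1cccc(CN2CC=C(CCC(=O)NO)C2=O)c1` gives 3330 nM in a functional assay on ACHN cells (Homo sapiens) for inhibition, read by sulforhodamine B assay; on this read-out lower numbers stand for stronger inhibition of growth and higher numbers for weaker inhibition of growth.
Compound 2 `O=C(CCC1=CCN(CCCc2ccc(Cl)cc2)C1=O)NO` gives 3330 nM.
Compound 3 `CCOc1ccc(CCCN2CC=C(CCC(=O)NO)C2=O)cc1` gives 3330 nM.

Compound 1 stands level with compounds 2 and 3 at the digits shown; none of the three is separated from another by more than the usual scatter. The step to compound 4 `O=C(CCC1=CCN(Cc2cccc(Cl)c2)C1=O)NO` is a single swap on the ring: chloro in place of methyl on an aromatic carbon. Going by the values given here, only one measured step exists to compare with, no change at the digits printed from compound 2 to compound 3 (within the scatter), and it also exchanges one ring substituent, there on compounds whose chain to the ring is longer than in compound 1. That step left the read-out unmoved, so for compound 4 the expected step of no change at the digits printed from compound 1 to compound 4 (within the scatter) is none beyond the scatter. Compound 4 is therefore estimated at 3330 nM, within 1500 nM to 7500 nM.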

Compound 4, concentration for 50% growth inhibition: 3330 nM
For compound 4 middle estimate and measured number coincide at the digits printed, and the stated range covers the measured number.
By their numbers in this assay, from the lowest: compounds 1, 2, 3 and 4 (each within the scatter of the next).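

Swapping methyl for chloro, meta to a large group on the aromatic ring, gives no change at the digits printed from compound 1 to compound 4 (within the scatter) in this assay. The earlier step exchanged a ring substituent on compounds with a longer chain to the ring, whereas this one shows the same flat result for a swap of one heavy atom on the shorter chain of compound 1. No measurement shown here offers an explanation for this. On these data alone, whether an amine or a carboxylic acid at this place would move the number remains open. So does whether any change to this ring matters in this assay.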